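Cytotoxicity of the amide side chain: toward compound 4

A few compounds are considered here, and "the series" means these few. Any claim that something is new, unique, unknown or untested is made for them only; others in the source may bear on it.

In an ADME assay on MT2 cells (Homo sapiens) for cytotoxicity (on this read-out lower numbers stand for higher toxicity in this test and higher numbers for lower toxicity in this test), compound 1 (`CCc1cc(CNC(=O)c2cc3nc(C)c([C@H](OC(C)(C)C)C(=O)O)c(-c4cc(F)c5c(c4C)CCCO5)n3n2)ccc1F`) gives > 40000 nM, which is a limit of the assay and not a number. Compound 2 (`Cc1nc2cc(C(=O)NCc3ccc(F)c(C4CC4)c3)nn2c(-c2cc(F)c3c(c2C)CCCO3)c1[C@H](OC(C)(C)C)C(=O)O`) returns > 40000 nM, also a limit. For compound 3 (`Cc1nc2cc(C(=O)NCc3ccc(F)cc3S(C)(=O)=O)nn2c(-c2cc(F)c3c(c2C)CCCO3)c1[C@H](OC(C)(C)C)C(=O)O`) the read-out is > 40000 nM, again a limit. All three therefore stand at the limit of > 40000 nM in this assay, at which 3 of the 3 values shown sit, and the steps between them cannot be sized: a step that the two limits leave unreadable from compound 1 to compound 2, a step that the two limits leave unreadable from compound 1 to compound 3 and a step that the two limits leave unreadable from compound 2 to compound 3.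

Compound 4 (`Cc1nc2cc(C(=O)NCCC(C)C)nn2c(-c2cc(F)c3c(c2C)CCCO3)c1[C@H](OC(C)(C)C)C(=O)O`) differs from compound 1 in one place: isobutyl in place of 3-ethyl-4-fluorophenyl on a saturated chain carbon bound to an amide-type nitrogen. Among the measured compounds shown here, no measured step bears directly on this change, since every comparison is capped by the limit. What the limits do show is that exchanging the group on the saturated chain carbon bound to the amide-type nitrogen, for a cyclopropyl-bearing ring or a methylsulfonyl-bearing ring, left the read-out at its limit in each case. The step that the limit leaves unreadable from compound 1 to compound 4 is therefore expected to be none beyond the scatter. The most likely outcome is that compound 4 is expected to return only a limit as well. Compound 4 is estimated at 50000 nM in this assay, within 20000 nM to 200000 nM.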

Compound 4, half-maximal cytotoxic concentration: > 40000 nM
Compound 4: only a limit was reported; the forecaster's own chance of this, stated with the estimate: 80%; the middle value does not contradict the limit.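

In this assay compound 4 gives > 40000 nM, which is a limit of the assay and not a number. No step among compound 1, compound 2, compound 3 and compound 4 can be read: the limit of > 40000 nM in this assay, at which 4 of the 4 values shown sit.

The compounds shown leave open how far each amide side chain lies from that limit, and whether any side chain gives a readable cytotoxic concentration.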